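This account rests on a few compounds, and the source may have more. Where it says the series, first, only, none or still open, it means among the compounds named here.

Measured so far in a physicochemical assay for lipophilicity, read by HPLC, using the shake flask method; on this read-out lower numbers stand for lower lipophilicity and higher numbers for higher lipophilicity:
compound 1, `CC(C)C/C(=N\C#N)N(C)Cc1ccc(Cl)nc1`: 1.75
compound 2, `CCCN(Cc1ccc(Cl)nc1)/C(C)=N/C#N`: 1.62

Compound 2 and compound 1 sit within the usual scatter of each other on this assay, so neither is distinguished from the other. For the measured compounds named here, no step between measured compounds is available.

Compound 3, `CCCCCN(Cc1ccc(Cl)nc1)/C(C)=N/C#N`, awaits measurement. It differs from compound 2 by ethyl in place of hydrogen on a saturated chain carbon, three bonds along the chain from an amine nitrogen. Going by the values given here, with no measured step to lean on, the expectation from compound 2 giving 1.62 is a step upward of a number 0.98 log units higher from compound 2 to compound 3 (beyond the scatter), well beyond the scatter. Compound 3 is therefore estimated at 2.6, expected to fall between 2.2 and 3.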

Compound 3, partition coefficient: 2.37
Compound 3: the middle estimate sits 0.23 log units above what was measured; measured number inside the range.
By their numbers in this assay, from the lowest: compounds 2 and 1 (each within the scatter of the next); then compound 3.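

In this assay, propyl to pentyl, ethyl in place of hydrogen on a saturated chain carbon, three bonds along the chain from an amine nitrogen, gives a number 0.75 log units higher from compound 2 to compound 3 (beyond the scatter) for this single change. For the compounds shown here, this is the first one-place step, and it shows that this position can move the read-out beyond the scatter. Nothing available explains the size of the step.

As far as these compounds go, whether a longer chain would extend the rise remains open. So does the outcome of placing a hydroxyl group or an amine at this position.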